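Replacing the chain amine with a carboxylic acid in an isoflavone

The compounds below may be only part of what the source reports. "The series", "measured", "known", "first", "only" and "open" are said of these compounds alone.

Compound 1, with the structure `NCCCCCCOc1ccc2c(=O)c(-c3ccc(O)cc3)coc2c1`, carries a long saturated chain ending in an amine. In an assay (Cricetulus griseus) for inhibition of Monoamine oxidase (Homo sapiens) (a higher number here means a weaker inhibitor, a lower number a stronger inhibitor), compound 1 reaches only the limit of the method, giving >> 9000 nM. Compound 2, `CCCCC(Oc1ccc2c(=O)c(-c3ccc(O)cc3)coc2c1)C(=O)OCC`, is the other measured member of this set. In this assay compound 2 likewise gives only the limit, >> 9000 nM. Going by the values given here, both known values therefore sit at the same place, as the line the limit of >> 9000 nM in this assay, at which 2 of the 2 values shown sit, records, so no step between measured compounds can be read here.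

Compound 3, `O=C(O)CCCCCCCOc1ccc2c(=O)c(-c3ccc(O)cc3)coc2c1`, is not yet measured. It differs from compound 1 as follows: carboxymethyl in place of amino on a saturated chain carbon, six bonds along the chain from an oxygen on an aromatic ring. With both neighbours at the limit, no change beyond the usual scatter is expected, and compound 3 is estimated to show a step that the limit leaves unreadable from compound 1 to compound 3. Compound 3 is thus expected at about 15000 nM, within 5000 nM to 50000 nM, with a fair chance that only a limit is reported.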

Compound 3, half-maximal inhibitory concentration: 6500 nM
For compound 3 the middle estimate is 2.3-fold (0.36 log units) above the measured one, within the range that was stated.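

In this assay, going by these compounds alone, compound 3 is the first compound in this set to give a measured number rather than a limit, so a chain ending in a carboxylic acid can be placed on the scale. Putting carboxymethyl in place of amino at this chain position gives an at least 1.3-fold lower number from compound 1 to compound 3 (0.14 log units; that floor lies within the scatter). This is only a floor, and its true size stays unread, as the value for compound 1 is a limit, as is the only other value in the set: the limit of >> 9000 nM in this assay, at which 2 of the 3 values shown sit.

The change adds chain carbons as well as the carboxylic acid, and the compounds shown do not separate these two parts. A longer chain ending in an amine, or a chain of the same length ending in an amide, would help to tell them apart.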